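Pyrazolyl for Pyridyl on an Inactive Tricyclic Core

This account rests on a few compounds, and the source may have more. Where it says the series, first, only, none or still open, it means among the compounds named here.

Compound 1 `c1ccc(-c2cccc3c2CCC3c2ncc[nH]2)nc1`: in a functional assay on CHO cells for agonist activity at Alpha-1D adrenergic receptor (Homo sapiens), read by FLIPR and calcium flux (on this read-out higher numbers stand for an effect only at larger amounts of compound and lower numbers for an effect already at smaller amounts), compound 1 gives > 10000 nM, which is a limit of the assay and not a number.
Compound 2 `Cn1nccc1-c1cccc2c1CCC2c1ncc[nH]1`: compound 2 gives > 10000 nM, also a limit.
Compound 3 `c1cncc(-c2cccc3c2CCC3c2ncc[nH]2)c1`: compound 3 gives > 10000 nM, again a limit.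

Compound 1 thus stands at the limit, and every other value known here sits there as well, as the limit of > 10000 nM in this assay, at which 3 of the 3 values shown sit, records. The change to compound 4 `Cn1cc(-c2cccc3c2CCC3c2ncc[nH]2)cn1` is 1-methyl-1H-pyrazol-4-yl in place of pyridin-2-yl on an aromatic carbon. The steps bearing on it are a step that the two limits leave unreadable from compound 1 to compound 2 and a step that the two limits leave unreadable from compound 1 to compound 3; neither can be sized, so no direction can be read for a two-nitrogen five-membered ring in this place. One therefore expects no readable step from compound 1 to compound 4, a step that the limit leaves unreadable from compound 1 to compound 4, with a further limit the most likely outcome. The estimate for compound 4 is 20000 nM, between 7000 nM and 60000 nM.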

Compound 4, half-maximal effective concentration: > 10000 nM
Compound 4 gave a limit, no number; the forecaster's own chance of this, stated with the estimate: 85%; the middle value lies beyond the limit too.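

Compound 4 also gives only a limit, so its steps from compound 1, compound 2 and compound 3 cannot be read: the limit of > 10000 nM in this assay, at which 4 of the 4 values shown sit.

The compounds shown leave open which change to the shared core, if any, would give a readable value.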